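Adding One Carbon to a Methoxy Group

The source may report more compounds than this note shows. Statements on the series, on what has been measured and on what is new or still open speak of the compounds shown alone.

- compound 1 `C=C(Br)C(=O)Nc1cccc(/C=C/C(=O)Nc2ccc(C)cc2)c1`: 270 nM
- compound 2 `C=C(Br)C(=O)Nc1cccc(/C=C/C(=O)Nc2ccc(OC)cc2)c1`: 26 nM

These values come from a functional assay on CCRF-CEM cells (Homo sapiens) for inhibition, read by MTT assay, with a stated time of 72 h; on this read-out lower numbers stand for stronger inhibition and higher numbers for weaker inhibition. Compound 2 holds the lower of the two numbers. For the measured compounds named here, the one measured step, a 10-fold lower number from compound 1 to compound 2 (1.02 log units; beyond the scatter), came with methoxy in place of methyl on an aromatic carbon. Compound 3 `C=C(Br)C(=O)Nc1cccc(/C=C/C(=O)Nc2ccc(OCC)cc2)c1` differs from compound 2 by a single change: methyl in place of hydrogen on a saturated chain carbon bound to an oxygen on an aromatic ring, which turns methoxy into ethoxy. Going by the values given here, that measured step shows that a small swap here can matter, but it is a different swap, and no ethoxy compound has been measured. A modest rise in this assay therefore seems likeliest, with a wide margin. The expected change is a 1.5-fold higher number from compound 2 to compound 3 (0.19 log units; within the scatter). Compound 3 is estimated at 40 nM, with an expected range of 13 nM to 120 nM.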

Compound 3, half-maximal inhibitory concentration: 98 nM
Beside the measured number, compound 3's estimate is 2.5-fold (0.39 log units) below it; measured number inside the range.
By their numbers in this assay, from the lowest: compound 2; then compound 3; then compound 1.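

Turning methoxy into ethoxy gave a 3.8-fold higher number from compound 2 to compound 3 (0.58 log units; beyond the scatter) in this assay, so a single added carbon on this oxygen-bound chain is enough to shift the number beyond the scatter. Ethoxy still keeps part of the gain seen with methoxy, as the swap from methyl shows a 2.8-fold lower number from compound 1 to compound 3 (0.44 log units; beyond the scatter) and places compound 3 in the middle of the series. Nothing available here explains why this added carbon has such an effect. As far as these compounds go, whether a longer chain such as propoxy would raise the number further remains open, as does the outcome with a hydroxy group or an amine in place of the alkoxy group.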